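A Longer Chain on a Weak Aortic Inhibitor

The source may report more compounds than this note shows. Statements on the series, on what has been measured and on what is new or still open speak of the compounds shown alone.

Compound 1 `N#Cc1cccc(Cn2nc(-c3ccc(CO)o3)c3ccccc32)c1`: 26000 nM
Compound 2 `CC(C)c1cnc(-c2nn(Cc3ccccc3F)c3ncccc23)nc1N`: 207000 nM

Of the compounds shown here, two have been measured in a functional assay (aorta) with Oryctolagus cuniculus as the target; a lower number here means a stronger inhibitor, a higher number a weaker inhibitor. Compound 1 gives 26000 nM, and compound 2 gives 207000 nM. Of the two numbers, that of compound 2 is the higher, and its distance from compound 1 lies well beyond the usual scatter of the measurement, so compound 2 is the weaker of the pair by a clear margin.

Compound 3 `N#CCCCCCc1cnc(-c2nn(Cc3ccccc3F)c3ncccc23)nc1N` has not yet been measured. It shares the core of compound 2 and differs from it in a single place: 5-cyanopentyl in place of isopropyl on an aromatic carbon. Within the data shown here, no measured pair in this set tells what such an exchange of a short branched group for a longer chain carrying a nitrile does to the read-out, so the expectation rests on compound 2 alone.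

Compound 3 is therefore expected to land near compound 2, with a step of a 1.4-fold lower number from compound 2 to compound 3 (0.14 log units; within the scatter) that may fall within the scatter or reach a little beyond it toward a lower number. Compound 3 is estimated at 150000 nM, with a range from 40000 nM to 500000 nM.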

Compound 3, half-maximal inhibitory concentration: 588000 nM
For compound 3 the middle estimate is 3.9-fold (0.59 log units) below the measured one, outside the stated range (above it).
By their numbers in this assay, from the lowest: compound 1; then compound 2; then compound 3.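

In this assay, the aromatic carbon ortho to an amino group and two atoms from the ring nitrogen proves sensitive to the group it carries: 5-cyanopentyl in place of isopropyl gives a 2.8-fold higher number from compound 2 to compound 3 (0.45 log units; beyond the scatter). The step is modest but beyond the scatter, and it runs toward a weaker inhibitor, so at least on this core the longer chain bearing a nitrile is not tolerated as well as the short branched group. Among these compounds, the earlier compounds offered no pair differing in one place, which makes this the first reading of any change at this position, and no measurement at hand speaks to the reason for it.

The compounds shown leave open whether the higher number goes with the length of the chain or with the nitrile at its end, since the two enter together in 5-cyanopentyl. A plain pentyl chain, or a chain ending in an amine or a carboxylic acid, would separate the two, while a methyl group at this carbon would show whether a smaller group moves the number the other way.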